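A few compounds are considered here, and "the series" means these few. Any claim that something is new, unique, unknown or untested is made for them only; others in the source may bear on it.

Measured compounds:
- compound 1, `CC(=O)c1nc([C@@H](O)[C@H](O)[C@H](O)CO)c(-c2ccccc2)[nH]1`: 3520 ng.h/mL
- compound 2, `CN(C)C(=O)c1nc([C@@H](O)[C@H](O)[C@H](O)CO)c[nH]1`: 1740 ng.h/mL

In an ADME assay on the whole organism (plasma, strain 129/SvEvBrd x C57BL/6) for pharmacokinetics, with Mus musculus as the target, at a dose of 10 mg/kg by the oral route (a lower number here means less compound in the circulation, a higher number more compound in the circulation at the dose given), compound 1 gives 3520 ng.h/mL and compound 2 gives 1740 ng.h/mL. Compound 2 thus stands at the lower of the two numbers, with compound 1 above it by a margin beyond the usual scatter. For the measured compounds named here, no step between compounds differing in one place is available, so the spread between these two rests on more than one structural change and gives no clean reading.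

Compound 3, `OC[C@@H](O)[C@@H](O)[C@H](O)c1c[nH]c(-c2cnccn2)n1`, is the next member, not yet measured. It differs from compound 2 as follows: pyrazin-2-yl in place of dimethylcarbamoyl on an aromatic carbon. Nothing among the measured pairs isolates this change, so no direction is supported by a shown step. On that basis the expected size of the step is none beyond the scatter, with the estimated step being a 1.3-fold higher number from compound 2 to compound 3 (0.10 log units; within the scatter). For compound 3 the expected value is therefore 2200 ng.h/mL, with a range from 800 ng.h/mL to 6000 ng.h/mL.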

Compound 3, area under the concentration-time curve: 1250 ng.h/mL
Beside the measured number, compound 3's estimate is 1.8-fold (0.25 log units) above it, within the range that was stated.
By their numbers in this assay, from the lowest: compounds 3 and 2 (each within the scatter of the next); then compound 1.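

In this assay, this position, an aromatic carbon between two ring nitrogen atoms, now has its first readable step: a 1.4-fold lower number from compound 2 to compound 3 (0.14 log units; within the scatter) on placing pyrazin-2-yl where dimethylcarbamoyl stood. The open group with no ring and the six-membered aromatic ring with 2 hetero atoms therefore leave compound 2 and compound 3 within the scatter of each other, so at this dose this carbon accepts either group without a measurable difference in the read-out. Nothing at hand gives a reason for this outcome.

From the compounds shown here alone, whether a carboxylic acid or a primary amine on this same carbon would also stay within the scatter remains open. Also open, going by these compounds, is whether pyrazin-2-yl would give the same reading on the core of compound 1, which differs from compound 3 in more than one place.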